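Methoxy to amino on the phenoxy ring: series notes

The compounds below may be only part of what the source reports. "The series", "measured", "known", "first", "only" and "open" are said of these compounds alone.

Measured so far in a functional assay on CCRF-CEM cells (Homo sapiens) for antiproliferative activity, read by cell counting, with a stated time of 96 h; on this read-out higher numbers stand for weaker inhibition and lower numbers for stronger inhibition:
compound 1, `COc1ccc(Oc2ccccc2NC(C)=C2C(=O)CC(c3ccccc3)CC2=O)cc1`, 120 nM
compound 2, `CC(Nc1ccccc1Oc1ccccc1)=C1C(=O)CC(c2ccccc2)CC1=O`, 170 nM

Compound 1 and compound 2 share the same core and differ only in that compound 2 carries hydrogen in place of methoxy on an aromatic carbon. The step of a 1.4-fold higher number from compound 1 to compound 2 (0.15 log units; within the scatter) lies within the scatter, so the two numbers cannot be ranked against each other; compound 1 simply sits at the lower end of a pair that is indistinguishable on this read-out.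

The next compound, compound 3, `CC(Nc1ccccc1Oc1ccc(N)cc1)=C1C(=O)CC(c2ccccc2)CC1=O`, is not yet measured. Compared with compound 1 it shows (amino in place of methoxy on an aromatic carbon). Among the measured compounds shown here, only one measured step bears on this position of the ring, the removal of methoxy in compound 2, and it was small. For the measured compounds named here, nothing measured speaks to an amino group at this place, so the sole guide is that changing this substituent so far moved the number little. No step beyond the scatter is therefore expected; the estimated step of a 1.3-fold higher number from compound 1 to compound 3 (0.10 log units; within the scatter) is meant as flat.

Compound 3 is estimated at 150 nM, with a range from 60 nM to 400 nM.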

Compound 3, half-maximal inhibitory concentration: 37 nM
Compound 3: middle estimate off by 4.1-fold (0.61 log units), on the high side, outside the stated range (below it).
By their numbers in this assay, from the lowest: compound 3; then compounds 1 and 2 (each within the scatter of the next).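

The position para to a large group on the phenoxy ring is not indifferent to its substituent, although methoxy and hydrogen could not be told apart there. In this assay, amino gives a 3.2-fold lower number from compound 1 to compound 3 (0.51 log units; beyond the scatter) and a 4.6-fold lower number from compound 2 to compound 3 (0.66 log units; beyond the scatter), both beyond the scatter, which makes compound 3 the strongest inhibitor of the three. Of the three groups compared at this place, only amino carries a hydrogen-bond donor, but this is a difference in what is counted and does not explain the step, and no supporting data bear on why the number falls.

As far as these compounds go, whether the lower number belongs to the amino group alone remains open, since a hydroxyl, a methylamino or a dimethylamino group at the same place would test how much of it persists when the nitrogen is changed or replaced. An acetamide or a carboxylic acid at this place, and an amino group elsewhere on the same ring, would show how narrowly the step depends on this group and this position.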